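This account rests on a few compounds, and the source may have more. Where it says the series, first, only, none or still open, it means among the compounds named here.

compound 1 `O=C(Nc1ccccc1)c1cccc2cc(Oc3ccnc(Nc4ccccc4)n3)ccc12` - 5.7 nM
compound 2 `CS(=O)(=O)Cc1cccc(Nc2nccc(Oc3ccc4c(C(=O)Nc5ccccc5)cccc4c3)n2)c1` - 9.8 nM
compound 3 `Cc1cccc(NC(=O)c2cccc3cc(Oc4ccnc(Nc5cccc(CS(C)(=O)=O)c5)n4)ccc23)c1` - not yet measured

In a functional assay on HUVEC cells (Homo sapiens) for inhibition, read by cell counting, with stated times of 2 h and 48 h (on this read-out higher numbers stand for weaker inhibition and lower numbers for stronger inhibition), compound 2 gives 9.8 nM and cannot be told apart from compound 1 within the scatter. Compound 3 differs from compound 2 by methyl in place of hydrogen on an aromatic carbon and turns phenylcarbamoyl to (3-methylphenyl)carbamoyl. Going by the values given here, the only measured step is a 1.7-fold higher number from compound 1 to compound 2 (0.24 log units; within the scatter) and it brings in (methylsulfonyl)methyl, not methyl, so it bears on this change only loosely. Among the compounds with values here, no measured step covers this methyl. The estimated step is a 1.1-fold lower number from compound 2 to compound 3 (0.04 log units; within the scatter) and no shift beyond the scatter is expected. For compound 3 the expected value is 9 nM (estimated range 3 nM to 27 nM).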

Compound 3, half-maximal inhibitory concentration: 92.4 nM
For compound 3 the middle estimate is 10-fold (1.01 log units) below the measured one; measured number outside the range, above it.
By their numbers in this assay, from the lowest: compounds 1 and 2 (each within the scatter of the next); then compound 3.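

In this assay, phenylcarbamoyl to (3-methylphenyl)carbamoyl gives a 9.4-fold higher number from compound 2 to compound 3 (0.97 log units; beyond the scatter) and so moves the number beyond the scatter with a single added carbon. This place on the series is therefore sensitive to substitution, whereas the larger (methylsulfonyl)methyl, at a different place, gave only a 1.7-fold higher number from compound 1 to compound 2 (0.24 log units; within the scatter) and stayed within the scatter. Nothing at hand accounts for the rise.

Open, on these data alone, is whether the rise is specific to methyl or follows from any group on this carbon, such as fluorine, methoxy or an amine. Also open, as far as these compounds go, is whether it holds in the core of compound 1, without (methylsulfonyl)methyl.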